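The source may report more compounds than this note shows. Statements on the series, on what has been measured and on what is new or still open speak of the compounds shown alone.

Three compounds of this series have been run in a functional assay on MCF7 cells (Homo sapiens) for cytotoxicity, read by sulforhodamine B assay, with a stated time of 48 h (on this read-out lower numbers stand for stronger inhibition of growth and higher numbers for weaker inhibition of growth), and the numbers spread across a wide band. Compound 1 `Cc1ccc2nc(/N=C3\C(=O)N(CN(c4ccccc4)c4ccccc4)c4ccccc43)sc2c1` gives 39200 nM in this assay, compound 2 `CCN(CC)CN1C(=O)C(=O)c2c(Br)cccc21` gives 20200 nM, and compound 3 `O=C1C(=O)N(CN(c2ccccc2)c2ccccc2)c2cccc(Br)c21` gives 110000 nM. Compound 3 stands at the highest number of the three: the nearest is compound 1, which sits lower by a margin beyond the scatter, and the furthest is compound 2, lower by a wider margin, also beyond the scatter. Within the data shown here, none of the three pairs differs in one place only, so no single step between measured compounds can be taken as a guide.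

The next compound, compound 4 `O=C1C(=O)N(CN(c2ccccc2)c2ccccc2)c2ccccc21`, is the closest relative of compound 3. The change is hydrogen in place of bromo on an aromatic carbon. Among the measured compounds shown here, compound 2 also carries bromo and sits lower than compound 3, but the two differ elsewhere as well, so that pair shows only its two values and no separate step.

With no measured step of this kind in hand, the expectation for the step from compound 3 to compound 4 in this assay is a small change, if any, within or at the edge of the scatter, leaning toward a somewhat lower number, a 1.4-fold lower number from compound 3 to compound 4 (0.14 log units; within the scatter). Compound 4 is therefore estimated at 80000 nM in this assay, expected to fall between 30000 nM and 200000 nM.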

Compound 4, concentration for 50% growth inhibition: 23700 nM
Estimate against measurement, compound 4: 3.4-fold (0.53 log units) above; the whole stated range lies above it.
By their numbers in this assay, from the lowest: compounds 2, 4 and 1 (each within the scatter of the next); then compound 3.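

In this assay, among these compounds, hydrogen in place of bromo on an aromatic carbon of the six-membered aromatic ring of carbon only gives a 4.6-fold lower number from compound 3 to compound 4 (0.67 log units; beyond the scatter), and this is the first step that can be read at a single place. With the rest of compound 3 held fixed, bromo at this position goes with weaker inhibition of growth than hydrogen, so the position is not indifferent to its substituent, although this reading rests on one pair alone. Nothing measured on these compounds bears on the reason for the step.

Open, on these data alone, is whether this shift is particular to bromo: chloro, methoxy or an amine at the same aromatic carbon, set against compound 4, would show whether other groups there also give a higher number than hydrogen. Open too, as far as these compounds go, is whether the step carries over to a different group on the core, which for compound 2 would take a partner carrying hydrogen in place of its bromo, with the diethylaminomethyl group kept unchanged.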